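Butyl in place of octyloxy: cytotoxicity expected at the limit

The compounds below may be only part of what the source reports. "The series", "measured", "known", "first", "only" and "open" are said of these compounds alone.

Of the compounds shown here, three sharing one core have been tested in an ADME assay on U2OS cells (Homo sapiens) for cytotoxicity; on this read-out lower numbers stand for higher toxicity in this test and higher numbers for lower toxicity in this test. Compound 1 `CCCCNc1ccc(C(=O)N/N=C/c2ccc([N+](=O)[O-])o2)cc1` carries a butylamino group on the aromatic ring, and in this assay compound 1 gives 12000 nM. Compound 2 `CCCCCCCCOc1ccc(C(=O)N/N=C/c2ccc([N+](=O)[O-])o2)cc1` carries octyloxy instead; for compound 2 this assay reports only a limit, > 200000 nM. Compound 3 `CCCCCCc1ccc(C(=O)N/N=C/c2ccc([N+](=O)[O-])o2)cc1` carries hexyl; for compound 3 the result is likewise a limit, > 200000 nM. Both steps away from compound 1 are large: an at least 16-fold higher number from compound 1 to compound 2 (1.22 log units; beyond the scatter) and an at least 16-fold higher number from compound 1 to compound 3 (1.22 log units; beyond the scatter). Between the two limits nothing can be read: a step that the two limits leave unreadable from compound 2 to compound 3. So compound 2 stands only at a limit, and one of the two other values is a limit as well, as the limit of > 200000 nM in this assay, at which 2 of the 3 values shown sit, shows.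

Compound 4 `CCCCc1ccc(C(=O)N/N=C/c2ccc([N+](=O)[O-])o2)cc1` is the next compound, and it differs from compound 2 by butyl in place of octyloxy on an aromatic carbon. Within the data shown here, the steps that bear on this are those from compound 1, where both an alkyl chain and an alkoxy chain gave large rises to the same limit, while the step between compound 2 and compound 3 stays unreadable. A plain butyl chain is therefore expected to behave like hexyl and octyloxy, and no step beyond the scatter is expected: a step that the limit leaves unreadable from compound 2 to compound 4. For compound 4 the expected value in this assay is 250000 nM, within 70000 nM to 900000 nM.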

Compound 4, half-maximal cytotoxic concentration: 19600 nM
For compound 4 the middle estimate is 13-fold (1.11 log units) above the measured one; measured number outside the range, below it.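

On this carbon of the ring, the length of the chain counts, not only the kind of atom that joins it to the ring: shortening hexyl to butyl gives an at least 10-fold lower number from compound 3 to compound 4 (1.00 log units; beyond the scatter), and butyl in place of octyloxy gives an at least 10-fold lower number from compound 2 to compound 4 (1.00 log units; beyond the scatter). The butyl group of compound 4 and the butylamino group of compound 1 cannot be told apart in this test, with a 1.6-fold higher number from compound 1 to compound 4 (0.21 log units; within the scatter), so replacing butylamino with an alkyl chain does not by itself raise the number, as compound 3 alone had suggested. Both steps down to compound 4 are minimum sizes only, because two of the compounds stand at a limit and not at a number: the limit of > 200000 nM in this assay, at which 2 of the 4 values shown sit.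

On these data alone, the steps between compounds at the limit cannot be read, so it stays open whether a pentyl chain would sit nearer to compound 4 or to compound 3. A butoxy group on the same carbon would help to separate the part played by the joining oxygen from that of chain length, which compound 2 and compound 3 cannot do.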